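Trifluoromethyl in Place of Fluoro: What to Expect

The source may hold more compounds than are shown below. What is called first, only, known or untested is meant among the compounds shown, and "the series" means these compounds.

In a functional assay on the whole organism (strain Swiss) with Mus musculus as the target, in the maximal electroshock model, with a stated time of 0.5 h, at a dose of 300 mg/kg by the intraperitoneal route (a higher number here means a stronger effect of the compound at the dose given, a lower number a weaker effect), compound 3 `CC(C(=O)N1CCN(c2cccc(F)c2)CC1)N1C(=O)CCC1=O` gives 50%. It stands level with compound 1 `COc1cccc(N2CCN(C(=O)C(C)N3C(=O)CCC3=O)CC2)c1`, which gives 50%, and with compound 2 `COCC(C(=O)N1CCN(c2cccc(C(F)(F)F)c2)CC1)N1C(=O)CCC1=O`, which gives 50%. Among the compounds with values here, the one measured step, no change at the digits printed from compound 1 to compound 3 (within the scatter), stayed within the scatter. Compound 4 `CC(C(=O)N1CCN(c2cccc(C(F)(F)F)c2)CC1)N1C(=O)CCC1=O` differs from compound 3 by trifluoromethyl in place of fluoro on an aromatic carbon. Within the data shown here, no measured step covers this exchange directly; compound 2 carries the same trifluoromethyl group on a different chain and reads the same as compound 3. Because no change at the digits printed from compound 1 to compound 3 (within the scatter) moved nothing, no step beyond the scatter is expected here either: no change at the digits printed from compound 3 to compound 4 (within the scatter). Compound 4 is therefore estimated at 50%, within a range from 30% to 70%.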

Compound 4, a percentage reported as activity, at one dose (the size of the read-out at that dose, not a potency): 100%
Compound 4: middle estimate off by 50 percentage points, on the low side; the measured number lies above the stated range.
By their numbers in this assay, from the lowest: compounds 1, 2 and 3 (each within the scatter of the next); then compound 4.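

In this assay trifluoromethyl on this aromatic carbon stands apart from the groups seen there before: the exchange for fluoro gives a number 50 percentage points higher from compound 3 to compound 4 (beyond the scatter) and the exchange for methoxy gives a number 50 percentage points higher from compound 1 to compound 4 (beyond the scatter) on the same chain. Compound 2 also carries trifluoromethyl, so that group alone does not set the level: hydrogen in place of the chain methoxy gives a number 50 percentage points higher from compound 2 to compound 4 (beyond the scatter) in this set.

On these data alone, whether chlorine or a nitrile on this aromatic carbon would read as high stays open, as does the effect of a longer chain on the saturated chain carbon. Nothing available explains why this exchange raises the number.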